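The compounds below may be only part of what the source reports. "The series", "measured", "known", "first", "only" and "open" are said of these compounds alone.

Compound 1 `COc1ccccc1-c1ccccc1O`: 54 ug/mL
Compound 2 `Nc1ccccc1-c1ccccc1O`: 54.1 ug/mL
Compound 3 `COc1ccc(-c2cccc(O)c2)cc1`: 14.6 ug/mL

In an ADME assay on HEK293 cells (Homo sapiens) for cytotoxicity, read by MTT assay, with a stated time of 3 days (on this read-out lower numbers stand for stronger inhibition and higher numbers for weaker inhibition), compound 1 gives 54 ug/mL and compound 2 gives 54.1 ug/mL. The change between them is amino in place of methoxy on an aromatic carbon and it made a 1.0-fold higher number from compound 1 to compound 2 (0.00 log units; within the scatter). Compound 3 gives 14.6 ug/mL in this assay; the difference between its core and the core of compound 1 is not broken down here. Compound 4 `Nc1ccc(-c2cccc(O)c2)cc1` has not been measured yet. It differs from compound 3 by amino in place of methoxy on an aromatic carbon, the same kind of change as from compound 1 to compound 2, though there the amino sits ortho to a group of 7 heavy atoms and here para to a group of 7 heavy atoms. Because a 1.0-fold higher number from compound 1 to compound 2 (0.00 log units; within the scatter) lay within the scatter, the step of a 1.0-fold higher number from compound 3 to compound 4 (0.01 log units; within the scatter) is expected to be small as well. Compound 4 is estimated at 15 ug/mL, between 7 ug/mL and 35 ug/mL.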

Compound 4, half-maximal inhibitory concentration: 55 ug/mL
For compound 4 the middle estimate is 3.7-fold (0.56 log units) below the measured one; measured number outside the range, above it.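

In this assay, amino in place of methoxy on an aromatic carbon gave a 3.8-fold higher number from compound 3 to compound 4 (0.58 log units; beyond the scatter) on the core of compound 3. So in this series the step seen on the core of compound 1 did not carry over to this second core, although that shows nothing about which difference between the two cores sets the steps apart, and two pairs give no rule for a third core. The two steps stand apart: the same change on two cores in this assay, a 1.0-fold higher number (0.00 log units; within the scatter) from compound 1 to compound 2 and a 3.8-fold higher number (0.58 log units; beyond the scatter) from compound 3 to compound 4, 3.8-fold (0.58 log units) apart, beyond the scatter of two such steps

The compounds shown leave open how a carboxylic acid or an acetamide would behave in place of methoxy on either core. They also leave open whether the amino-for-methoxy step on a further core would resemble either of these two.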